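The source may hold more compounds than are shown below. What is called first, only, known or untested is meant among the compounds shown, and "the series" means these compounds.

Compound 1 `CC(C)(C)c1cc2c(N/N=C/c3ccc(C(=O)O)cc3)ncnc2s1`: 7.22 ug/mL
Compound 2 `CC(C)(C)c1cc2c(N/N=C/c3ccc(CO)cc3)ncnc2s1`: 0.556 ug/mL

In a functional assay on PC-6 cells (Homo sapiens) for cytotoxicity, read by MTT assay, with a stated time of 3 days (on this read-out lower numbers stand for stronger inhibition and higher numbers for weaker inhibition), compound 2 stands lowest of the two numbers shown. Among the compounds with values here, the only measured step is a 13-fold lower number from compound 1 to compound 2 (1.11 log units; beyond the scatter), a large one. Compound 3 `CC(C)(C)c1cc2c(N/N=C/c3ccc(O)cc3)ncnc2s1` carries hydroxy in place of hydroxymethyl on an aromatic carbon. Within the data shown here, no measured step bears directly on this change: the one step known exchanges carboxy for hydroxymethyl, not hydroxymethyl for hydroxy, so it gives no direction for the present change. Compound 3 is therefore expected to show a 1.4-fold higher number from compound 2 to compound 3 (0.16 log units; within the scatter), no change beyond the scatter. Compound 3 is estimated at 0.8 ug/mL, within a range from 0.2 ug/mL to 3 ug/mL.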

Compound 3, half-maximal inhibitory concentration: > 10 ug/mL
Compound 3: no number, only a limit; the forecaster's own chance of this, stated with the estimate: 5%; middle value at least 12-fold (1.09 log units) away from the limit.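

In this assay, the position para to a large group does not accept hydroxy for hydroxymethyl, a change of one carbon: an at least 17-fold higher number from compound 2 to compound 3 (1.25 log units; beyond the scatter). For compound 3 the read-out is a limit, not a number: the limit of > 10 ug/mL in this assay, at which 1 of the 3 values shown sits.

The other new step gives only a floor, an at least 1.3-fold higher number from compound 1 to compound 3 (0.14 log units; that floor lies within the scatter), so the two groups in that step cannot be put in order, while hydroxymethyl alone among the three gives the low number.

On these data alone, whether an amine, a methoxy group or a longer chain such as hydroxyethyl at this position would keep the low number of compound 2 stays open.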